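The source may report more compounds than this note shows. Statements on the series, on what has been measured and on what is new or still open speak of the compounds shown alone.

Compound 2 (`COc1cc(-c2nn(-c3cccc(NC(=O)c4cccc(C(F)(F)F)c4)c3)cc2-c2ccncc2)ccc1Cl`) gives 1020 nM in a functional assay on SF-295 cells (Homo sapiens) for inhibition, read by sulforhodamine B assay, with a stated time of 48 h; a lower number here means a stronger inhibitor, a higher number a weaker inhibitor. Among the compounds with values here, the only other value shown comes from compound 1 (`O=C(Nc1cccc(-n2cc(-c3ccncc3)c(-c3ccc(Cl)c(O)c3)n2)c1)Nc1cccc(C(F)(F)F)c1`), which gives 960 nM in this assay, and compound 2 stands within the usual scatter of that number. Compound 3 (`COc1cc(-c2nn(-c3cccc(NC(=O)Nc4ccc(Cl)c(Cl)c4)c3)cc2-c2ccncc2)ccc1Cl`) differs from compound 2 by (3,4-dichlorophenyl)amino in place of 3-(trifluoromethyl)phenyl on a carbonyl carbon. Within the data shown here, no measured pair shows this change, so no step can be read from the data. Since compound 1 also carries an amino group on the carbonyl carbon and gives 960 nM, the expected step is a 1.1-fold lower number from compound 2 to compound 3 (0.05 log units; within the scatter), which stays within the scatter. Compound 3 is estimated at 900 nM, between 300 nM and 3000 nM.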

Compound 3, half-maximal inhibitory concentration: 690 nM
Estimate against measurement, compound 3: 1.3-fold (0.12 log units) above; the range from low to high includes it.
By their numbers in this assay, from the lowest: compounds 3, 1 and 2 (each within the scatter of the next).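

In this assay, (3,4-dichlorophenyl)amino in place of 3-(trifluoromethyl)phenyl on a carbonyl carbon gives a 1.5-fold lower number from compound 2 to compound 3 (0.17 log units; within the scatter). This is the first pair shown that differs in only this one place, and the step shows that this swap leaves the number within the scatter. No evidence is at hand to explain the result. As far as these compounds go, the amino nitrogen and the two chlorines enter together, so their separate contributions remain unknown. Also open, from the compounds shown here alone, is how a carboxylic acid or a longer carbon chain would fare on this carbonyl carbon.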